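Methyl to Ethyl Ester in a Cell Viability Screen

This account rests on a few compounds, and the source may have more. Where it says the series, first, only, none or still open, it means among the compounds named here.

Compound 1, `COC(=O)/C=C\NC(=O)[C@@H](O)C(C)(C)CO`, was tested in an ADME assay on WI-38 cells (Homo sapiens) for inhibition, read by CellTiter-Glo, with a stated time of 48 h, tested at 100 uM (a higher number here means more inhibition at the concentration tested (going by the name of the read-out), a lower number less inhibition), and gave -20%. Of the two compounds with a number in this assay, compound 1 stands lowest; its nearest neighbour is compound 2, `CC(C)(CO)[C@@H](O)C(=O)N/C=C\C(=O)OCc1ccccc1`, which in this assay gives 4%, a number lying beyond the scatter above compound 1. Compound 3, `COC(=O)/C=C\NC(=O)[C@H](O)C(C)(C)CO`, has in this assay the entry "not determined" (no result reported), that is, no result reported. Its relation to compound 1 rests on (the fact that compounds 1 and 3 differ only in the configuration as drawn), but without a number for compound 3 nothing can be drawn from that pair.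

Compound 4, `CCOC(=O)/C=C\NC(=O)[C@@H](O)C(C)(C)CO`, has not yet been measured in this assay. It differs from compound 1 by methyl in place of hydrogen on a saturated chain carbon bound to an oxygen next to a carbonyl group. No step between two measured compounds carries this change, so its effect is not known from the data shown. Both compounds 1 and 2 give low numbers in this assay, and the change is a small one, so the step of a number 8 percentage points higher from compound 1 to compound 4 (within the scatter) is expected to stay within the scatter, with no direction favoured. Compound 4 is therefore estimated at -12%, with a range from -35% to 15%.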

Compound 4, a percentage reported as inhibition, at one concentration (the size of the read-out at that concentration, not a potency): -6%
Estimate against measurement, compound 4: 6 percentage points below, within the range that was stated.
By their numbers in this assay, from the lowest: compound 1; then compounds 4 and 2 (each within the scatter of the next).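

In this assay, within the data shown here, the change from methoxycarbonyl to ethoxycarbonyl gives the first step that can be read between two measured compounds, a number 14 percentage points higher from compound 1 to compound 4 (beyond the scatter), which shows that this saturated chain carbon bound to an oxygen next to a carbonyl group is a place where methyl in place of hydrogen moves the number. The move is modest, and compound 4, at -6%, lies within the scatter of compound 2, at 4%, leaving compound 1 alone at the low end of the three numbers. Nothing in the information available explains why this change shifts the read-out.

Among these compounds, with only this one step at the position, it remains open whether a longer chain such as propyl, or a carboxylic acid in place of the ester, would extend the shift, leave the number unchanged or reverse it. The role of the configuration also remains open, as the pair that could address it offers a number on only one side: the fact that compounds 1 and 3 differ only in the configuration as drawn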